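The source may hold more compounds than are shown below. What is called first, only, known or untested is meant among the compounds shown, and "the series" means these compounds.

Of the compounds shown here, three built on a shared core have been tested in a functional assay on PC-9 cells (Homo sapiens) for inhibition, read by MTT assay, with a stated time of 48 h, tested at 10 uM; on this read-out higher numbers stand for more inhibition at the one concentration tested (going by the name of the read-out) and lower numbers for less inhibition. Compound 1, `COc1cc(NC(=O)Nc2cc(Nc3ccc(C(C)(C)C)cc3)ncn2)cc(OC)c1`, gives 74.1%. Compound 3, `COc1cc(NC(=O)Nc2cc(Nc3cc(C(F)(F)F)ccc3OC)ncn2)cc(OC)c1`, gives 81.1%. Compound 2, `Cc1ccc(Nc2cc(NC(=O)Nc3c(Cl)cccc3Cl)ncn2)cc1C`, gives 92.1%, the highest of the three; its gap to the nearest, compound 3, and its gap to the furthest, compound 1, both lie beyond the usual scatter of such measurements. Compound 4, `COc1ccc(Br)cc1Nc1cc(NC(=O)Nc2c(Cl)cccc2Cl)ncn1`, has not yet been measured in this assay. It differs from compound 2 in one place: 5-bromo-2-methoxyphenyl in place of 3,4-dimethylphenyl on a nitrogen on an aromatic ring. The rest of compound 2 is kept unchanged. Going by the values given here, no pair of measured compounds differs in only one place, so the size of such a step has no direct precedent here. A modest fall is nevertheless expected, because compound 3 gives 81.1% while compound 2 gives 92.1%, although those two differ in more than one place. The expected step of a number 12.1 percentage points lower from compound 2 to compound 4 (beyond the scatter) is thus estimated to lie near the edge of the scatter. Compound 4 is estimated to give 80% in this assay, with a range from 62% to 94%.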

Compound 4, a percentage reported as inhibition, at one concentration (the size of the read-out at that concentration, not a potency): 69%
For compound 4 the middle estimate is 11 percentage points above the measured one; the measured number falls inside the stated range.
By their numbers in this assay, from the lowest: compounds 4, 1 and 3 (each within the scatter of the next, the first and the last beyond it); then compound 2.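

The change from 3,4-dimethylphenyl to 5-bromo-2-methoxyphenyl on a nitrogen on an aromatic ring, with the rest of the molecule kept unchanged, gives in this assay a number 23.1 percentage points lower from compound 2 to compound 4 (beyond the scatter). Going by these compounds alone, this is the first step in the set that isolates a single place, and it shows that the read-out responds to the group on this nitrogen when nothing else is altered. No measurement shown here bears on why the number falls.

Going by these compounds, whether the fall follows the bromine, the methoxy group or the two together stays open, and one step cannot show whether the change would act alike with the other groups seen on the shared core. Also open, on these data alone, is how a phenyl ring carrying an amine or a carboxylic acid would read at this nitrogen.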